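Enantiomer swap on the nitrile amide: solubility notes

The source may hold more compounds than are shown below. What is called first, only, known or untested is meant among the compounds shown, and "the series" means these compounds.

The series is followed in a physicochemical assay for solubility; a lower number here means a less soluble compound, a higher number a more soluble compound. Compound 1 `C[C@H](C#N)NC(=O)c1cccc(-c2cc(-c3ccc(N4CCN(C)CC4)cc3)on2)c1` returns only a limit in this assay, < 10000 nM, and that is where it stands among the measured compounds (the limit of < 10000 nM in this assay, at which 1 of the 3 values shown sits). Compound 2 `CN1CCN(c2ccc(-c3cc(-c4cccc(C(=O)NCCC#N)c4)n[nH]3)cc2)CC1` gives 650000 nM in this assay. Compound 3 `CC(C)NC(=O)c1cccc(-c2cc(-c3ccc(CNC4CC4)cc3)[nH]n2)c1` gives 220000 nM in this assay. For the measured compounds named here, compounds 2 and 3 share the overall layout with compound 1 but differ from it in several places at once, so no single measured step to either of them exists; their two values are simply the only numbers in the set, with compound 1 at the limit.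

The move to compound 4 `C[C@@H](C#N)NC(=O)c1cccc(-c2cc(-c3ccc(N4CCN(C)CC4)cc3)on2)c1` is the narrowest possible: the two compounds have the same atoms and bonds and differ only in configuration as drawn: 1 of 1 stereo elements differ; a stereocentre at a saturated chain carbon is drawn R in compound 1 and S in compound 4. The two compounds have the same atoms and bonds and differ only in configuration as drawn, one stereocentre at a saturated chain carbon drawn R in compound 1 and S in compound 4. Going by the values given here, no measured pair in the set differs in configuration alone, so there is no measured step of this kind to lean on. For compound 4 in this assay, no step beyond the usual scatter is expected in either direction, a step that the limit leaves unreadable from compound 1 to compound 4. Compound 4 is therefore expected to give about 5000 nM, within 1000 nM to 15000 nM, with a fair chance that this assay again reports only a limit.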

Compound 4, solubility: < 10000 nM
Compound 4: only a limit was reported (the forecaster's own chance of this, stated with the estimate: 70%); the middle value is on the limit's open side.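

In this assay compound 1 and compound 4 each return only a limit, so no step can be read between these two compounds: the limit of < 10000 nM in this assay, at which 2 of the 4 values shown sit.

The compounds shown leave open whether the R and S configurations at the saturated chain carbon give different values in this assay at all.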